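The compounds below may be only part of what the source reports. "The series", "measured", "known", "first", "only" and "open" are said of these compounds alone.

Three compounds of one shared core have been run through a functional assay on K562 cells (Homo sapiens) for antiproliferative activity, read by MTT assay, with a stated time of 48 h; a lower number here means a stronger inhibitor, a higher number a weaker inhibitor. Compound 1, whose structure is `N#CC1=C(N)Oc2cc3oc(-c4ccccc4)cc(=O)c3c(O)c2C12C(=O)Nc1cc(Br)ccc12`, gives 8700 nM in this assay. Compound 2, with the structure `COc1ccc(-c2cc(=O)c3c(O)c4c(cc3o2)OC(N)=C(C#N)C42C(=O)N(C)c3ccc(C)cc32)c(OC)c1`, gives 12200 nM. Compound 3, drawn as `CCN1C(=O)C2(C(C#N)=C(N)Oc3cc4oc(-c5ccc(OC)cc5OC)cc(=O)c4c(O)c32)c2cc(Cl)ccc21`, gives 8450 nM. The number for compound 3 is the lowest of the three, yet compound 1 sits almost on top of it and compound 2 is not separated from it beyond the scatter of the measurement, so the three compounds cannot be placed in any order on these results.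

Compound 4, with the structure `CCN1C(=O)C2(C(C#N)=C(N)Oc3cc4oc(-c5ccc(OC)cc5OC)cc(=O)c4c(O)c32)c2cc(Br)ccc21`, has not yet been measured. It differs from compound 3 in a single place: bromo in place of chloro on an aromatic carbon, a bromo in place of chloro on an aromatic carbon. Going by the values given here, no measured pair in this set shows exactly this exchange, so no step of known size can be read off. Compound 1 carries a bromo at a comparable site and shows a number close to that of compound 3, which suggests that the exchange leaves the activity largely where it is. The step from compound 3 to compound 4 is therefore expected to be a 1.1-fold lower number from compound 3 to compound 4 (0.02 log units; within the scatter), within the scatter in either direction. Compound 4 is estimated to give 8000 nM, in the range from 4000 nM to 16000 nM.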

Compound 4, half-maximal inhibitory concentration: 16100 nM
For compound 4 the middle estimate is 2.0-fold (0.30 log units) below the measured one, outside the stated range (above it).
By their numbers in this assay, from the lowest: compounds 3, 1, 2 and 4 (each within the scatter of the next).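

Going by these compounds alone, the pair of compound 3 and compound 4 is the first in the set that differs in one place, so it gives the first direct reading at this aromatic carbon, which lies meta to a fused ring and para to a fused ring on a six-membered aromatic ring of carbon only. In this assay, the exchange of chloro for bromo at this site gives a 1.9-fold higher number from compound 3 to compound 4 (0.28 log units; within the scatter), so on this core and with this read-out the two halogens cannot be told apart, even though the step is larger than the earlier comparison across differing compounds had suggested. Nothing available on these compounds speaks to what lies behind the size of this step.

On these data alone, a single exchange between two halogens says little about how much this position tolerates, and what an amine, a carboxylic acid or a longer chain such as propyl on this aromatic carbon would do to the number remains open. Also open, as far as these compounds go, is whether the same exchange of bromo for chloro would give a step of similar size on a core with a different group elsewhere.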